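A few compounds are considered here, and "the series" means these few. Any claim that something is new, unique, unknown or untested is made for them only; others in the source may bear on it.

Compound 1 `N#Cc1cc(-c2nc(C(c3ccc(F)cc3)c3ccc(F)cc3)sc2CC(=O)O)ccc1F` is tested in an in vitro functional assay on HEK285-7 cells for antagonist activity at prostaglandin D2 receptor 2 (Homo sapiens), read by BRET and beta-arrestin recruitment (a lower number here means a stronger inhibitor, a higher number a weaker inhibitor), where compound 1 gives 520 nM. Among the three measured compounds compound 1 stands second highest: compound 2 `Cc1nc(-c2ccc(Cl)cc2)c(CC(=O)O)s1` gives 41000 nM, and compound 3 `O=C(O)Cc1sc(C(c2ccc(F)cc2)c2ccc(F)cc2)nc1-c1ccnc(F)c1` gives 4.7 nM. Compound 4 `O=C(O)Cc1sc(C(c2ccc(F)cc2)c2ccc(F)cc2)nc1-c1ccnc(Cl)c1` differs from compound 1 by 2-chloropyridin-4-yl in place of 3-cyano-4-fluorophenyl on an aromatic carbon. Among the measured compounds shown here, one measured step bears directly on this change, a 110-fold lower number from compound 1 to compound 3 (2.04 log units; beyond the scatter), which replaced the same 3-cyano-4-fluorophenyl on the same aromatic carbon with 2-fluoropyridin-4-yl. For the measured compounds named here, the group entering in compound 4 is a 2-chloropyridin-4-yl, close in kind to the one that entered in compound 3, so a comparably large fall in this assay is expected. The expected step is an 87-fold lower number from compound 1 to compound 4 (1.94 log units; beyond the scatter). Compound 4 is therefore estimated at 6 nM, in a range from 1.5 nM to 25 nM.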

Compound 4, half-maximal inhibitory concentration: 39 nM
For compound 4 the middle estimate is 6.5-fold (0.81 log units) below the measured one, and the stated range ends below it.
By their numbers in this assay, from the lowest: compound 3; then compound 4; then compound 1; then compound 2.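

With 2-chloropyridin-4-yl entering on this aromatic carbon, a 13-fold lower number from compound 1 to compound 4 (1.12 log units; beyond the scatter) in this assay shows that the gain over 3-cyano-4-fluorophenyl does not depend on fluoro alone. The halogen still matters: an 8.3-fold higher number from compound 3 to compound 4 (0.92 log units; beyond the scatter) accompanies chloro in place of fluoro, so the two pyridinyl groups are not interchangeable here. Nothing measured here accounts for that gap. The compounds shown leave open how 2-bromopyridin-4-yl, 2-methoxypyridin-4-yl or a pyridin-4-yl carrying no halogen would compare at this position.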